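This account rests on a few compounds, and the source may have more. Where it says the series, first, only, none or still open, it means among the compounds named here.

In a functional assay on NUGC-3 cells (Homo sapiens) for antiproliferative activity, read by XTT assay (a lower number here means a stronger inhibitor, a higher number a weaker inhibitor), compound 1 `O=c1c(Cc2coc3cccc(OCC4CCCCC4)c3c2=O)coc2ccccc12` gives 3530 nM and compound 2 `Cc1ccc2c(=O)c(Cc3coc4cccc(OCC5CCCCC5)c4c3=O)coc2c1` gives 2150 nM as its reading, so the two stand within the usual scatter of each other and compound 1 has no clear rank. Compound 3 `COc1cccc2occ(Cc3coc4ccccc4c3=O)c(=O)c12` differs from compound 1 at one place, with cyclohexylmethoxy cut back to methoxy: hydrogen in place of cyclohexyl on a saturated chain carbon bound to an oxygen on an aromatic ring is the whole change. Among the compounds with values here, the one measured step, a 1.6-fold lower number from compound 1 to compound 2 (0.22 log units; within the scatter) for methyl in place of hydrogen on an aromatic carbon, leaves the cyclohexylmethoxy untouched, so it offers only a weak guide. Within the data shown here, no measured compound lacks the cyclohexyl, so the direction is a cautious guess: a higher number, meaning weaker inhibition, is expected. The estimated step is a 2.0-fold higher number from compound 1 to compound 3 (0.30 log units; within the scatter) and carries wide uncertainty. For compound 3 the expected value is 7000 nM with a range of 2000 nM to 25000 nM as the estimate.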

Compound 3, half-maximal inhibitory concentration: 3190 nM
For compound 3 the middle estimate is 2.2-fold (0.34 log units) above the measured one, within the range that was stated.
By their numbers in this assay, from the lowest: compounds 2, 3 and 1 (each within the scatter of the next).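

Cutting cyclohexylmethoxy back to methoxy removes an entire six-membered ring of carbon, yet in this assay the change is a 1.1-fold lower number from compound 1 to compound 3 (0.04 log units; within the scatter) and so cannot be told apart from the scatter of repeated measurements. The step between compound 1 and compound 2 left the cyclohexylmethoxy untouched, so this pair gives the only view of this position, and here the cyclohexyl makes no clear difference to the reading. No supporting evidence bears on why the reading holds without that ring.

Only cyclohexylmethoxy and methoxy are shown at this place, so a longer chain such as butoxy, or a chain ending in an amine or a carboxylic acid, could still read differently. From the compounds shown here alone, whether the same holds alongside the methyl of compound 2 also remains open.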